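The source may report more compounds than this note shows. Statements on the series, on what has been measured and on what is new or still open speak of the compounds shown alone.

Measured so far in an assay on isolated protein for inhibition of serine/threonine-protein kinase PLK1 (Homo sapiens), read by radiometric assay and 33P incorporation, with a stated time of 40 min, tested at 20 uM, in the presence of a further agent that is not named here; a higher number here means more inhibition at the concentration tested (going by the name of the read-out), a lower number less inhibition:
compound 1 `CCNc1cc(-c2ccc(NC(=O)Nc3ccc(C)cc3)cc2C)ccn1` gives 47.5%;
compound 2 `CCNc1cc(-c2ccc(NC(=O)Nc3ccc(C(F)(F)F)cc3)cc2C)ccn1` gives 54.8%;
compound 3 `CCNc1cc(-c2ccc(NC(=O)Nc3cccc(Cl)c3)cc2C(F)(F)F)ccn1` gives 94.9%.

Compound 3 stands highest of the three, and its distance from compound 1 and from compound 2 lies beyond the scatter. Compound 4 `CCNc1cc(-c2ccc(NC(=O)Nc3ccccc3Cl)cc2C(F)(F)F)ccn1` differs from compound 3 in a single place: 2-chlorophenyl in place of 3-chlorophenyl on an amide-type nitrogen. For the measured compounds named here, no measured step covers this change. Going by the values given here, the only measured step, a number 7.3 percentage points higher from compound 1 to compound 2 (within the scatter), concerns a different group on a different ring and lies within the scatter, so it offers no guide to the size of the present step. Compound 4 is expected to remain near its parent's level, perhaps somewhat lower, giving an estimated step of a number 14.9 percentage points lower from compound 3 to compound 4 (beyond the scatter). Compound 4 is therefore estimated at 80%, with a range from 50% to 98% in this assay .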

Compound 4, a percentage reported as inhibition, at one concentration (the size of the read-out at that concentration, not a potency): 71.6%
Compound 4: middle estimate off by 8.4 percentage points, on the high side; the measured number falls inside the stated range.
By their numbers in this assay, from the lowest: compounds 1 and 2 (each within the scatter of the next); then compound 4; then compound 3.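

In this assay, putting 2-chlorophenyl in place of 3-chlorophenyl on the amide-type nitrogen gives a number 23.3 percentage points lower from compound 3 to compound 4 (beyond the scatter). For the compounds shown here, the atoms stay the same, so where the chlorine sits on this ring matters, whereas the only earlier step, a number 7.3 percentage points higher from compound 1 to compound 2 (within the scatter), swapped one group for another and did not clear the scatter. Nothing measured here explains the drop.

Going by these compounds, what remains open is whether a fluorine or a methoxy group in place of the chlorine would hold the level of compound 3.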